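Sulfonyl swap from compound 2 to compound 3

The source may hold more compounds than are shown below. What is called first, only, known or untested is meant among the compounds shown, and "the series" means these compounds.

Measured so far in a physicochemical assay for lipophilicity, using the shake flask method, measured as octanol-water partition, at pH 7.4; a lower number here means a more polar compound, a higher number a more lipophilic compound:
compound 1 `CC(=O)N[C@H]1[C@H]([C@@H](O)[C@H](O)CNC(=O)c2ccc(Cl)cc2)O[C@@](OCc2cccc(F)c2F)(C(=O)O)C[C@@H]1O` at -0.27
compound 2 `O=C(NC[C@@H](O)[C@H](O)[C@@H]1O[C@@](OCc2cccc(F)c2F)(C(=O)O)C[C@H](O)[C@H]1NS(=O)(=O)c1ccccc1[N+](=O)[O-])c1ccc(Cl)cc1` at 0.87

Going by the values given here, of the two measured compounds, compound 2 stands highest at 0.87 in this assay and compound 1 is its only neighbour. The next compound is compound 3 `CS(=O)(=O)N[C@H]1[C@H]([C@@H](O)[C@H](O)CNC(=O)c2ccc(Cl)cc2)O[C@@](OCc2cccc(F)c2F)(C(=O)O)C[C@@H]1O`, and the change is methyl in place of 2-nitrophenyl on a sulfonyl sulfur. Among the compounds with values here, one measured step bears on it: (2-nitrophenyl)sulfonyl in place of acetyl on an amine nitrogen gave a number 1.14 log units higher from compound 1 to compound 2 (beyond the scatter) and this large step lies beyond the scatter. That single step does not separate the sulfonyl from the 2-nitrophenyl. With the 2-nitrophenyl gone, a large step of similar size is expected in the opposite direction, downward in this assay as a result. The estimated change is a number 1.07 log units lower from compound 2 to compound 3 (beyond the scatter) on this reading. For compound 3 the estimated value is -0.2 with an expected range from -0.7 to 0.3 for now.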

Compound 3, distribution coefficient: -0.17
The estimate for compound 3 lay 0.03 log units below the measured number; the measured number falls inside the stated range.
By their numbers in this assay, from the lowest: compounds 1 and 3 (each within the scatter of the next); then compound 2.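

Keeping the sulfonyl and replacing 2-nitrophenyl with methyl on the sulfonyl sulfur gives, in this assay, a number 1.04 log units lower from compound 2 to compound 3 (beyond the scatter), which separates the two parts of the earlier change from acetyl to (2-nitrophenyl)sulfonyl. Methylsulfonyl in place of acetyl on the amine nitrogen gives a number 0.10 log units higher from compound 1 to compound 3 (within the scatter), so compound 1 and compound 3 cannot be told apart here, and among these three compounds the large steps go with the 2-nitrophenyl rather than with the sulfonyl link itself. Nothing in hand gives a reason for the size of these steps.

Still open, from the compounds shown here alone, is whether the aromatic ring or the nitro group on it carries the step. A plain phenyl on the sulfonyl sulfur, or a phenyl bearing an amine in place of the nitro group, would bear on that question.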